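Removing the last halogen from the anilino ring

This account rests on a few compounds, and the source may have more. Where it says the series, first, only, none or still open, it means among the compounds named here.

Of the compounds shown here, three sharing one core have been tested in a functional assay on A549 cells (Homo sapiens) for antiproliferative activity, read by MTT assay, with a stated time of 72 h; a higher number here means a weaker inhibitor, a lower number a stronger inhibitor. Compound 1 `COc1cc2ncnc(Nc3ccc(Cl)c(C(F)(F)F)c3)c2cc1OCCCCC(=O)Nc1ccc(S(N)(=O)=O)cc1` gives 9270 nM. Compound 3 `COc1cc2ncnc(Nc3ccc(F)c(Br)c3)c2cc1OCCCCC(=O)Nc1ccc(S(N)(=O)=O)cc1` gives 16000 nM. Compound 2 `COc1cc2ncnc(Nc3ccc(Cl)cc3)c2cc1OCCCCC(=O)Nc1ccc(S(N)(=O)=O)cc1` reached only the limit of this assay, > 40000 nM, so no exact number is known for it, and it stands as the weakest inhibitor of the three. The step of an at least 4.3-fold higher number from compound 1 to compound 2 (0.63 log units; beyond the scatter) shows that stripping the trifluoromethyl from the anilino ring weakens inhibition, and the step of an at least 2.5-fold lower number from compound 2 to compound 3 (0.39 log units; beyond the scatter) shows that putting halogens back on that ring recovers part of it. The step of a 1.7-fold higher number from compound 1 to compound 3 (0.24 log units; within the scatter) is small.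

Compound 4 `COc1cc2ncnc(Nc3ccccc3)c2cc1OCCCCC(=O)Nc1ccc(S(N)(=O)=O)cc1` goes one step further than compound 2: hydrogen in place of chloro on an aromatic carbon. The measured steps that bear on this change point the same way: each time a substituent was taken off the anilino ring, the number in this assay rose. Compound 2 already sits at the limit (the limit of > 40000 nM in this assay, at which 1 of the 3 values shown sits), so any further weakening cannot be resolved by this assay. A step that the limit leaves unreadable from compound 2 to compound 4 is expected, most likely reported once more as a limit rather than a number. Compound 4 is therefore estimated at 60000 nM, with a range from 30000 nM to 150000 nM.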

Compound 4, half-maximal inhibitory concentration: > 40000 nM
Compound 4: a limit, no number; the forecaster's own chance of this, stated with the estimate: 85%; the middle value does not contradict the limit.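

With chloro gone, the anilino ring of compound 4 carries no substituent at all, and in this assay compound 4 gives only a limit of the assay, > 40000 nM. The unsubstituted phenyl ring sits clearly on the weaker side of both rings that carry two halogen-containing groups, with an at least 2.5-fold higher number from compound 3 to compound 4 (0.39 log units; beyond the scatter) and an at least 4.3-fold higher number from compound 1 to compound 4 (0.63 log units; beyond the scatter), so among the four compounds only those two rings give a readable number. The steps between compound 2 and compound 4 cannot be read, so it remains unknown whether chloro alone adds anything over hydrogen at this place on the ring, and the measurement cannot settle that point: the limit of > 40000 nM in this assay, at which 2 of the 4 values shown sit.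

The compounds shown leave open whether a single group of another kind on this ring, such as a nitrile or a methyl group, would bring the number back within the range of the assay. They also leave open whether a carboxylic acid in place of the sulfonamide, or a shorter chain linking it to the core, would change how much the anilino ring matters.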